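Adding a Chloro Group to Compound 2

This account rests on a few compounds, and the source may have more. Where it says the series, first, only, none or still open, it means among the compounds named here.

In a functional assay on DWD cells (Homo sapiens) for inhibition, read by sulforhodamine B assay (on this read-out lower numbers stand for stronger inhibition of growth and higher numbers for weaker inhibition of growth), compound 1 (`Cc1ccc2[nH]c(-c3ccc(-c4ccc(-c5cccc(Cl)c5)cc4)cc3)nc2c1`) gives 2510 nM and compound 2 (`Oc1cccc2[nH]c(-c3ccc(-c4ccc(-c5ccccc5)cc4)cc3)nc12`) gives 9680 nM as the higher of the two numbers, a gap beyond the usual scatter. These two compounds differ in more than one place, so the gap cannot be tied to any single change.

Compound 3 (`Oc1cccc2[nH]c(-c3ccc(-c4ccc(-c5cccc(Cl)c5)cc4)cc3)nc12`) has not been measured yet. It comes from compound 2 through one change, chloro in place of hydrogen on an aromatic carbon, which turns phenyl to 3-chlorophenyl. The new group sits on a six-membered aromatic ring of carbon only, meta to a large group.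

Among the measured compounds shown here, no measured pair shows this change alone. Compound 1 carries the same 3-chlorophenyl on a different core and gives 2510 nM as the lower number, which is only a weak hint. The expected 2.2-fold lower number from compound 2 to compound 3 (0.33 log units; beyond the scatter) is a modest drop toward stronger inhibition of growth, perhaps only just beyond the scatter. For compound 3 the estimated value is 4500 nM with an expected range of 1800 nM to 11000 nM in repeated measurements.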

Compound 3, concentration for 50% growth inhibition: 2100 nM
The estimate for compound 3 lay 2.1-fold (0.33 log units) above the measured number; the range from low to high includes it.
By their numbers in this assay, from the lowest: compounds 3 and 1 (each within the scatter of the next); then compound 2.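

In this assay, among the compounds shown here, the change from phenyl to 3-chlorophenyl gives a 4.6-fold lower number from compound 2 to compound 3 (0.66 log units; beyond the scatter), and this is the first reading of chloro in place of hydrogen on an aromatic carbon with the rest of the molecule held the same. Compounds 1 and 2 differ in more than one place, so they could only hint at this, whereas the new pair shows that a single chlorine at this position, on a six-membered aromatic ring of carbon only and meta to a large group, is enough to strengthen growth inhibition by more than the usual scatter. No supporting measurement is available to explain why the chlorine has this effect.

From the compounds shown here alone, this is one step at one position on one core, so it remains open whether the same change would have a similar effect on the core of compound 1 or at another place on the ring. Going by these compounds, it is also open how other groups would compare with chloro at this position, such as fluoro, methoxy, an amine or a carboxylic acid.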